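Truncation of the amide substituent in a piperazine carboxamide series

The source may hold more compounds than are shown below. What is called first, only, known or untested is meant among the compounds shown, and "the series" means these compounds.

Measured compounds:
compound 1 `C[C@H]1CN(c2ncc(C(=O)NCc3ccc(F)c(F)c3)cc2Cl)CCN1C1CCN(Cc2ccc(Cl)cc2)CC1` — 6 nM
compound 2 `CNC(=O)c1cnc(N2CCN(C3CCN(Cc4ccc(Cl)cc4)C(=O)C3)[C@@H](C)C2)c(Cl)c1` — 7000 nM

In a functional assay for antagonist activity at C-X-C chemokine receptor type 3 (Homo sapiens) (a lower number here means a stronger inhibitor, a higher number a weaker inhibitor), compound 1 gives 6 nM, the lowest of the two numbers shown, and compound 2 gives 7000 nM, a gap beyond the scatter; the two differ in more than one place, so no single step can be read from them. Compound 3 `C[C@H]1CN(c2ncc(C(N)=O)cc2Cl)CCN1C1CCN(Cc2ccc(Cl)cc2)CC1` is not yet measured. It differs from compound 1 by hydrogen in place of 3,4-difluorobenzyl on an amide-type nitrogen. For the measured compounds named here, with no single-change step in hand, a clear loss of potency is expected, as in the direction of compound 2 with its 7000 nM. Compound 3 is therefore estimated at 2000 nM, in the range 300 nM to 15000 nM, a step of a 330-fold higher number from compound 1 to compound 3 (2.52 log units; beyond the scatter).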

Compound 3, half-maximal inhibitory concentration: 39 nM
Beside the measured number, compound 3's estimate is 51-fold (1.71 log units) above it; measured number below the stated range.
By their numbers in this assay, from the lowest: compound 1; then compound 3; then compound 2.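

In this assay the 3,4-difluorobenzyl on the amide-type nitrogen proves useful but not essential: hydrogen in its place gives a 6.5-fold higher number from compound 1 to compound 3 (0.81 log units; beyond the scatter), a modest loss. Compound 3 still gives 39 nM as a bare carbamoyl, so much of the potency of compound 1 does not depend on this group. Open, as far as these compounds go, is whether a plain benzyl, a phenethyl chain or a cyclopropyl on this nitrogen would recover the difference, and whether the two fluorines contribute to it. Nothing at hand explains the size of this step.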